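A few compounds are considered here, and "the series" means these few. Any claim that something is new, unique, unknown or untested is made for them only; others in the source may bear on it.

Measured compounds:
Compound 1 `Clc1ccc(CNc2nc(NCc3ccc(Cl)cc3)c3ccccc3n2)cc1` — in a functional assay on MDA-MB-231 cells (Homo sapiens) for cytotoxicity, read by neutral red uptake, with a stated time of 72 h (a higher number here means a weaker inhibitor, a lower number a stronger inhibitor), compound 1 gives 4260 nM
Compound 2 `CCNc1nc(SCC)nc2ncccc12` — in this assay compound 2 gives 18700 nM

Of the two compounds with numbers in this assay, compound 2 stands at the highest value; its nearest neighbour is compound 1, whose number is lower by a margin that lies beyond the usual scatter of such measurements. The two compounds share no common core, so the gap between them is simply what the two values show and is not traced to any single change.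

Compound 3 `CCCCCNc1nc(SCC)nc2ncccc12` is the untested partner of compound 2. The difference between them is propyl in place of hydrogen on a saturated chain carbon, two bonds along the chain from a nitrogen on an aromatic ring, and everything else in the structure is kept. Among the compounds with values here, no pair of measured compounds differs by such a change, so there is no measured step to lean on. The account therefore expects at most a modest step in this assay, and leans toward a somewhat lower number for compound 3 than for compound 2, while allowing that the change could fall within the scatter. The step expected from compound 2 to compound 3 in this assay is a 2.1-fold lower number from compound 2 to compound 3 (0.32 log units; beyond the scatter). For compound 3 in this assay the estimate is 9000 nM, with a range from 3000 nM to 30000 nM.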

Compound 3, half-maximal inhibitory concentration: 1300 nM
Beside the measured number, compound 3's estimate is 6.9-fold (0.84 log units) above it; the measured number lies below the stated range.
By their numbers in this assay, from the lowest: compound 3; then compound 1; then compound 2.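

Replacing hydrogen with propyl on a saturated chain carbon, two bonds along the chain from a nitrogen on an aromatic ring, turns ethylamino into pentylamino and gives a 14-fold lower number from compound 2 to compound 3 (1.16 log units; beyond the scatter) in this assay. Within the data shown here, this is the only measured step at this position, and it shows that the number responds strongly to this change in the chain, with everything else in the structure kept, though a single pair cannot show a trend with chain length. Nothing available here offers an explanation for the size of this step.

The compounds shown leave open how the number follows chain length, whether it keeps falling or turns back, and a butylamino or a hexylamino chain on the same core would help to settle that. They also leave open what a branched chain of the same size, or a pentylamino chain carrying a hydroxyl group or an amine, would give in this assay.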